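Removing the Methyl: Expected Cytotoxicity of Compound 4

The compounds below may be only part of what the source reports. "The series", "measured", "known", "first", "only" and "open" are said of these compounds alone.

Measured compounds:
- compound 1, `N=c1c(=O)[nH]nc2n1CCN2c1ccccc1Cl`, 0%
- compound 2, `N=c1c(=O)[nH]nc2n1CCN2c1ccc(Cl)cc1`, 27%
- compound 3, `Cc1ccc(N2CCn3c2n[nH]c(=O)c3=N)cc1`, 0%

Three compounds sharing one core were examined in a functional assay on T47D cells (Homo sapiens) for cytotoxicity, with a stated time of 72 h, tested at 50 ug/mL; a lower number here means a weaker effect, a higher number a stronger effect of the compound at the concentration tested. Compound 1 gives 0%, compound 2 gives 27%, and compound 3 gives 0%. Compound 3 stands level with compound 1 at the digits shown, and the two together form the lowest of the three numbers; compound 2 lies above both, and the single step that connects two of these compounds in one change, a number 27 percentage points lower from compound 2 to compound 3 (beyond the scatter), is beyond the scatter though modest in size.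

The next compound, compound 4, `N=c1c(=O)[nH]nc2n1CCN2c1ccccc1`, is not yet measured in this assay. It differs from compound 3 in one place: hydrogen in place of methyl on an aromatic carbon.

Among the measured compounds shown here, no measured step exchanges methyl for hydrogen, so the only guidance is indirect. The step from compound 2 to compound 3 shows that a change at this aromatic carbon can move the read-out by a modest amount, but compound 3 already sits at the floor of the scale, so a further drop cannot be seen. Compound 4 is therefore expected to stay near compound 3, with a number 5 percentage points higher from compound 3 to compound 4 (within the scatter) as the estimated step, which lies within the scatter. The estimate for compound 4 is 5%, ranging from 0% to 25%.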

Compound 4, a percentage reported as inhibition, at one concentration (the size of the read-out at that concentration, not a potency): 3%
Compound 4: middle estimate off by 2 percentage points, on the high side, within the range that was stated.
By their numbers in this assay, from the lowest: compounds 1, 3 and 4 (each within the scatter of the next); then compound 2.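

In this assay, among the compounds shown here, compound 4 gives the first reading with hydrogen on this aromatic carbon, para to a large group, and hydrogen in place of methyl gives a number 3 percentage points higher from compound 3 to compound 4 (within the scatter), so the two groups are not told apart here. Hydrogen in place of chloro at the same carbon gives a number 24 percentage points lower from compound 2 to compound 4 (beyond the scatter), which matches the earlier a number 27 percentage points lower from compound 2 to compound 3 (beyond the scatter) and leaves chloro as the only one of these three groups at this place that stands clear of the others, with compound 2 at 27%. Chloro does not have that standing at every carbon of the ring, though, since hydrogen in place of the chloro of compound 1, which sits at another aromatic carbon, gives a number 3 percentage points higher from compound 1 to compound 4 (within the scatter).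

The compounds shown leave open whether the higher reading belongs to chloro alone or would also appear with fluoro, bromo, methoxy, an amine or a carboxylic acid on this carbon, and a single read-out at one concentration gives no potency for any of them. Nothing shown explains why chloro at this carbon stands apart from methyl and hydrogen.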